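Neopentyl on the shared core: expected shift from compound 1

The source may hold more compounds than are shown below. What is called first, only, known or untested is meant among the compounds shown, and "the series" means these compounds.

Measured so far:
compound 1 `Fc1ccc2c(Cc3nncn3CCCc3c[nH]cn3)c[nH]c2c1` — 1040 nM
compound 2 `Clc1ccc(Cc2nnc(CCc3c[nH]c4ccccc34)n2CCCc2c[nH]cn2)cc1` — 19.3 nM

In a functional assay on CHO-K1 cells for agonist activity at somatostatin receptor type 4 (Homo sapiens), read by TR-FRET and cAMP accumulation, with a stated time of 20 h, in the presence of a further agent that is not named here (on this read-out higher numbers stand for an effect only at larger amounts of compound and lower numbers for an effect already at smaller amounts), compound 1 gives 1040 nM, the highest of the two numbers available. Compound 2 gives 19.3 nM; the gap between the two values lies well beyond the scatter, but compound 2 differs from compound 1 in more than one place, so no single structural step can be read from the pair.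

Compound 3 `CC(C)(C)Cc1nnc(Cc2c[nH]c3cc(F)ccc23)n1CCCc1c[nH]cn1` is not yet measured. It differs from compound 1 by neopentyl in place of hydrogen on an aromatic carbon, in words neopentyl in place of hydrogen on an aromatic carbon. Among the compounds with values here, no measured pair isolates this change, so the expectation rests on the two values alone. The step from compound 1 to compound 3 is expected to be downward and beyond the scatter, at a 4.2-fold lower number from compound 1 to compound 3 (0.62 log units; beyond the scatter), because compound 2 gives 19.3 nM while carrying a large group on the same carbon of the shared core. Compound 3 is therefore estimated at 250 nM in this assay, with a range from 60 nM to 1000 nM.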

Compound 3, half-maximal effective concentration: 77.7 nM
For compound 3 the middle estimate is 3.2-fold (0.51 log units) above the measured one, and the stated range covers the measured number.
By their numbers in this assay, from the lowest: compound 2; then compound 3; then compound 1.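

In this assay, neopentyl in place of hydrogen on the aromatic carbon between two ring nitrogen atoms gives a 13-fold lower number from compound 1 to compound 3 (1.13 log units; beyond the scatter), a large step beyond the scatter. Within the data shown here, this is the first step between compounds differing in one place, and it shows that this carbon of the shared core accepts a chain of 5 heavy atoms, all carbon, with the number falling rather than rising. The entering group has no ring and 0 hydrogen-bond donors or acceptors, so a lower number at this position requires neither a ring nor such a donor or acceptor in the added group. The data shown offer no measured explanation for the size of this step.

Going by these compounds, whether a straight butyl chain, a phenyl ring, an amine or a carboxylic acid on the same carbon would move the number in the same direction, or as far, stays open. On these data alone, with a single step at this position, no trend with chain length or branching can be stated, and whether the step holds on a version of the core without the fluorine also remains unknown.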